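Replacing the phenoxy group of compound 2

The source may report more compounds than this note shows. Statements on the series, on what has been measured and on what is new or still open speak of the compounds shown alone.

Measured so far in a physicochemical assay for lipophilicity, using the shake flask method, in phosphate buffer, measured as octanol-water partition, with a stated time of 30 min, at pH 7.4; a higher number here means a more lipophilic compound, a lower number a more polar compound:
- Compound 1 `Cc1nccn1-c1cnc(NCc2c(F)ccc3c2CCO3)c2cn[nH]c(=O)c12`: 2.1
- Compound 2 `Fc1ccc2c(c1CNc1ncc(Oc3ccccc3)c3nncn13)CCO2`: 3.5
- Compound 3 `CN(C)Cc1ccc2c(c1)CN(c1cnc(NCc3c(F)ccc4c3CCO4)n3cnnc13)C2=O`: 1.6

Compound 2 stands highest of the three, and both other compounds lie below it by more than the scatter. Compound 4 `CC1(C)CC(=O)N(c2cnc(NCc3c(F)ccc4c3CCO4)n3cnnc23)C1` has not yet been measured. It carries 4,4-dimethyl-2-oxopyrrolidin-1-yl in place of phenoxy on an aromatic carbon. Going by the values given here, no measured pair isolates this change, so the only guide is that compound 1 at 2.1 and compound 3 at 1.6, neither with phenoxy, sit lower. A downward step beyond the scatter is therefore expected. The expected change is a number 1.10 log units lower from compound 2 to compound 4 (beyond the scatter). For compound 4 the estimated value is 2.4, with an expected range of 1.9 to 2.9.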

Compound 4, distribution coefficient: 2
For compound 4 the middle estimate is 0.40 log units above the measured one; low and high end bracket the measured number.
By their numbers in this assay, from the lowest: compound 3; then compounds 4 and 1 (each within the scatter of the next); then compound 2.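

In this assay, going by these compounds alone, placing 4,4-dimethyl-2-oxopyrrolidin-1-yl in place of phenoxy on this aromatic carbon gives a number 1.50 log units lower from compound 2 to compound 4 (beyond the scatter) and provides the first step in which only this position changes. The drop is large even though the two groups have the same hydrogen-bond donor and acceptor counts. No measurement shown here accounts for the size of this step. Going by these compounds, what the two methyl groups of the entering group contribute remains open. So does where a methoxy group or a carboxylic acid on this aromatic carbon would fall in this assay.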